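The compounds below may be only part of what the source reports. "The series", "measured", "known", "first", "only" and "open" are said of these compounds alone.

Measured compounds:
compound 1 `CCNc1cc(-c2ccc(NC(=O)Nc3ccc(OC)cc3)cc2C)ccn1` — 45.8%
compound 2 `CCNc1cc(-c2ccc(NC(=O)Nc3ccc(C)cc3)cc2C(F)(F)F)ccn1` — 42.6%
compound 3 `CCNc1cc(-c2ccc(NC(=O)Nc3cccc(Cl)c3)cc2C(F)(F)F)ccn1` — 94.9%

In an assay on isolated protein for inhibition of serine/threonine-protein kinase PLK1 (Homo sapiens), read by radiometric assay and 33P incorporation, with a stated time of 40 min, tested at 20 uM, in the presence of a further agent that is not named here (on this read-out lower numbers stand for less inhibition and higher numbers for more inhibition at the one concentration tested (going by the name of the read-out)), compound 3 gives the highest of the three numbers. Compound 1 stands far below it, and compound 2 further still. Among the compounds with values here, the one single-point step among the measured compounds runs a number 52.3 percentage points higher from compound 2 to compound 3 (beyond the scatter), a large gain that arrives with the 3-chlorophenyl group on the amide-type nitrogen.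

Compound 4 `CCNc1cc(-c2ccc(NC(=O)Nc3ccc(OC)cc3)cc2C(F)(F)F)ccn1` has not yet been measured in this assay. It differs from compound 3 in one place: 4-methoxyphenyl in place of 3-chlorophenyl on an amide-type nitrogen. This change moves back from the 3-chlorophenyl group that accompanied the large step toward a group of the kind seen in compounds 1 and 2, which carry a 4-methoxyphenyl and a 4-methylphenyl group on that nitrogen. Compound 1 with a 4-methoxyphenyl group gives 45.8%, and compound 2 with a 4-methylphenyl group gives 42.6%; the two values lie within the scatter of one another.

Compound 4 is therefore expected to fall well below compound 3, with an estimated step of a number 49.9 percentage points lower from compound 3 to compound 4 (beyond the scatter). For compound 4 the estimated value in this assay is 45%, within a range from 25% to 70%.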

Compound 4, a percentage reported as inhibition, at one concentration (the size of the read-out at that concentration, not a potency): 62.1%
For compound 4 the middle estimate is 17.1 percentage points below the measured one, and the stated range covers the measured number.
By their numbers in this assay, from the lowest: compounds 2 and 1 (each within the scatter of the next); then compound 4; then compound 3.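

In this assay, 3-chlorophenyl and 4-methoxyphenyl on an amide-type nitrogen can now be compared directly, with the rest of the molecule unchanged, and the read-out runs a number 32.8 percentage points lower from compound 3 to compound 4 (beyond the scatter); the group at this position therefore matters, although compound 4 does not drop to the level of compounds 1 and 2. Compound 4 also resolves the two differences between those compounds, which could not be separated before: methoxy in place of methyl on an aromatic carbon gives a number 19.5 percentage points higher from compound 2 to compound 4 (beyond the scatter), while trifluoromethyl in place of methyl on an aromatic carbon gives a number 16.3 percentage points higher from compound 1 to compound 4 (beyond the scatter), so each of these modest changes moves the number in its own right. Nothing shown here accounts for any of these steps.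

Within the data shown here, it remains open whether 3-chlorophenyl would hold its advantage with methyl in place of trifluoromethyl on the aromatic carbon, since the gain from trifluoromethyl has been seen only with 4-methoxyphenyl. Going by these compounds, it is also open whether the large step follows the chlorine or its place on the ring, a question that 4-chlorophenyl and 3-methoxyphenyl groups on the same nitrogen would address.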